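The source may hold more compounds than are shown below. What is called first, only, known or untested is meant among the compounds shown, and "the series" means these compounds.

- compound 1 `CN(C)c1ccc2cc(-c3ccccc3F)c(N)nc2c1`: > 500 mL/min/kg (a limit)
- compound 2 `CN(C)c1ccc2cc(-c3ccc(Cl)cc3)c(N)nc2c1`: 290 mL/min/kg

Both results come from an ADME assay on microsomes from liver (Mus musculus) for metabolic stability, read by HPLC, with a stated time of 4 h; on this read-out lower numbers stand for slow clearance and higher numbers for fast clearance. Within the data shown here, compound 2 gives 290 mL/min/kg and holds the only true number so far. Compound 1 stands at a limit of the assay (> 500 mL/min/kg) and not at a number.

Compound 3 `CN(C)c1ccc2cc(-c3ccccn3)c(N)nc2c1` carries pyridin-2-yl in place of 4-chlorophenyl on an aromatic carbon, ortho to an amino group (pyridin-2-yl in place of 4-chlorophenyl on an aromatic carbon). Among the measured compounds shown here, one measured step bears on this change. It swaps a group on the same carbon: an at least 1.7-fold lower number from compound 1 to compound 2 (0.23 log units; that floor lies within the scatter) with 4-chlorophenyl in place of 2-fluorophenyl. That single step sets no firm size or direction for a different swap, so no step beyond the scatter is expected in this assay. For compound 3 the expected step is (a 1.3-fold lower number from compound 2 to compound 3 (0.12 log units; within the scatter)). Compound 3 is estimated at 220 mL/min/kg within a range from 100 mL/min/kg to 480 mL/min/kg (an expectation, not a measurement).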

Compound 3, clearance: > 500 mL/min/kg
Compound 3 gave a limit, no number (the forecaster's own chance of this, stated with the estimate: 10%); middle value at least 2.2-fold (0.35 log units) from the limit.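

In this assay, putting pyridin-2-yl in place of 4-chlorophenyl on this carbon, ortho to an amino group, gives an at least 1.7-fold higher number from compound 2 to compound 3 (0.23 log units; that floor lies within the scatter). That floor alone does not prove a real change, but it does show that swapping the carbon-only ring for one holding a ring nitrogen brings no visible gain here, and that of the three groups shown on this carbon, only 4-chlorophenyl yields a true number. Compound 1 and compound 3 each stand at a limit, so the step between them cannot be read: the limit of > 500 mL/min/kg in this assay, at which 2 of the 3 values shown sit.

Going by these compounds, the true distance between compound 2 and compound 3 remains open. So does what a plain phenyl, a pyridin-2-yl ring bearing a chlorine, or a phenyl ring bearing a carboxylic acid or an amine would give on this carbon.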